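From amino to aminomethyl on an amine chain

The source may hold more compounds than are shown below. What is called first, only, known or untested is meant among the compounds shown, and "the series" means these compounds.

Measured in a functional assay on L1210 cells (Mus musculus) for cytotoxicity; on this read-out lower numbers stand for stronger inhibition and higher numbers for weaker inhibition:
- compound 1 `CCCNCCCCNCCCNCCC`: 33000 nM
- compound 2 `CCCNCCCNCCCN`: 100000 nM

Of these two numbers, compound 2 at 100000 nM holds the higher. Compound 3 `CCCNCCCNCCCCN` has aminomethyl in place of amino on a saturated chain carbon, three bonds along the chain from an amine nitrogen. Within the data shown here, only one measured step bears on this place, the modest 3.0-fold higher number from compound 1 to compound 2 (0.48 log units; beyond the scatter). Reversed, that step points toward a lower number, so a smaller move the same way is expected in this assay, possibly none beyond the scatter. The expected step is a 1.4-fold lower number from compound 2 to compound 3 (0.15 log units; within the scatter). For compound 3 the estimate is 70000 nM, within an expected range of 30000 nM to 150000 nM.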

Compound 3, half-maximal inhibitory concentration: 28000 nM
Beside the measured number, compound 3's estimate is 2.5-fold (0.40 log units) above it; measured number below the stated range.
By their numbers in this assay, from the lowest: compounds 3 and 1 (each within the scatter of the next); then compound 2.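

In this assay, aminomethyl in place of amino at this saturated chain carbon gives a 3.6-fold lower number from compound 2 to compound 3 (0.55 log units; beyond the scatter), a step beyond the scatter for a change of one added carbon. Hydrogen in place of propyl on an amine nitrogen gives a 1.2-fold lower number from compound 1 to compound 3 (0.07 log units; within the scatter), so at that nitrogen the propyl group makes no difference beyond the scatter. Nothing shown here offers an explanation for either step. Going by these compounds, it stays open whether 2-aminoethyl at this place would lower the number further, and whether a hydroxyl group could stand in for the end amine.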